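Swapping one aryl group on a weakly active compound

The source may hold more compounds than are shown below. What is called first, only, known or untested is meant among the compounds shown, and "the series" means these compounds.

In a functional assay on CAPAN-1 cells (Homo sapiens) for antiproliferative activity, with a stated time of 72 h (on this read-out higher numbers stand for weaker inhibition and lower numbers for stronger inhibition), compound 1 `Nc1ncnn2c([C@@H]3O[C@H](CO)[C@@H](O)[C@H]3O)cc(C#CC3CC3)c12` gives 20 nM, compound 2 `Nc1ncnn2c([C@@H]3O[C@H](CO)[C@@H](O)[C@H]3O)cc(C#Cc3ccccc3)c12` gives 37700 nM, and compound 3 `Nc1ncnn2c([C@@H]3O[C@H](CO)[C@@H](O)[C@H]3O)cc(-c3ccc(F)cc3)c12` gives 65600 nM. Compound 3 thus stands at the high end of these numbers, alongside compound 2. The large moves are a 3300-fold higher number from compound 1 to compound 3 (3.52 log units; beyond the scatter) and a 1900-fold higher number from compound 1 to compound 2 (3.28 log units; beyond the scatter). Compound 4 `Nc1ncnn2c([C@@H]3O[C@H](CO)[C@@H](O)[C@H]3O)cc(-c3ccccc3Cl)c12` changes one group of compound 3: 2-chlorophenyl in place of 4-fluorophenyl on an aromatic carbon. Neither group is the 2-cyclopropylethynyl of compound 1, so the better guide is the small step among the compounds without it, a 1.7-fold higher number from compound 2 to compound 3 (0.24 log units; within the scatter). The expected change in this assay is therefore none beyond the scatter, an estimated 1.3-fold lower number from compound 3 to compound 4 (0.12 log units; within the scatter). Compound 4 is expected at 50000 nM, with an estimated range of 12000 nM to 120000 nM.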

Compound 4, half-maximal inhibitory concentration: 54900 nM
For compound 4 the middle estimate is 1.1-fold (0.04 log units) below the measured one; measured number inside the range.
By their numbers in this assay, from the lowest: compound 1; then compounds 2, 4 and 3 (each within the scatter of the next).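

In this assay, 2-chlorophenyl in place of 4-fluorophenyl gives a 1.2-fold lower number from compound 3 to compound 4 (0.08 log units; within the scatter), and 2-chlorophenyl in place of 2-phenylethynyl gives a 1.5-fold higher number from compound 2 to compound 4 (0.16 log units; within the scatter), so neither swap separates these compounds. Among the four compounds, only the 2-cyclopropylethynyl group stands apart, with a 2700-fold higher number from compound 1 to compound 4 (3.44 log units; beyond the scatter). No measurement shown here explains that gap.

Still open, as far as these compounds go, is whether an amine or a plain ethynyl group on this aromatic carbon would give a number near that of compound 1 or near those of the other three compounds.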